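A Difluorophenyl Amide Tested Against a Row of Limits

This account rests on a few compounds, and the source may have more. Where it says the series, first, only, none or still open, it means among the compounds named here.

Three measured compounds share one core and differ only in the group on the amide nitrogen. Compound 1 `Cc1cccc2sc(NC(=O)COc3ccc(/C=C4\SC(=O)NC4=O)cc3)nc12` in a functional assay on PC-3 cells (Homo sapiens) for inhibition (on this read-out higher numbers stand for weaker inhibition of growth and lower numbers for stronger inhibition of growth), gives > 100000 nM, which is a limit of the assay and not a number. Compound 2 `O=C(COc1ccc(/C=C2\SC(=O)NC2=O)cc1)Nc1cccc([N+](=O)[O-])c1` in this assay gives > 100000 nM, again a limit. Compound 3 `O=C(COc1ccc(/C=C2\SC(=O)NC2=O)cc1)Nc1ccccc1` in this assay gives > 100000 nM, also a limit. Among the measured compounds shown here, the single measured step, a step that the two limits leave unreadable from compound 2 to compound 3, therefore cannot be read in size or direction. Compound 3 thus stands together with the other two at the limit described by the limit of > 100000 nM in this assay, at which 3 of the 3 values shown sit.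

Compound 4 `O=C(COc1ccc(/C=C2\SC(=O)NC2=O)cc1)Nc1ccc(F)cc1F` arises from compound 3 by the change (2,4-difluorophenyl in place of phenyl on an amide-type nitrogen). For the measured compounds named here, no measured step involves fluorine, and the one step that was measured gives no readable size, so nothing among the measured compounds points to a change beyond the scatter in this assay. Compound 4 is therefore expected to give an estimated 100000 nM, within 40000 nM to 300000 nM, most probably again reported as a limit. This estimate corresponds to an expected step of a number no higher from compound 3 to compound 4 (the limit leaves the size open).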

Compound 4, concentration for 50% growth inhibition: > 100000 nM
Compound 4 was reported as a limit; the forecaster's own chance of this, stated with the estimate: 80%; the middle value lies on the limit itself.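

In this assay compound 4 gives > 100000 nM, a limit of the assay and not a number. The steps to compound 4 from compound 3 and from compound 2 therefore cannot be read. The compounds shown leave open whether any amide substituent on the shared core gives a measurable value: the limit of > 100000 nM in this assay, at which 4 of the 4 values shown sit.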